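This account rests on a few compounds, and the source may have more. Where it says the series, first, only, none or still open, it means among the compounds named here.

Compound 1, `CCC(C)[C@H](NCCN)c1cc(C(F)(F)F)ccc1N1CCN(C(=O)CCc2ccc(Cl)cc2Cl)CC1`: 56 nM
Compound 2, `CCC(C)[C@H](NC[C@H](C)N)c1cc(C(F)(F)F)ccc1N1CCN(C(=O)CCc2ccc(Cl)cc2Cl)CC1`: 89 nM
Compound 3, `CCC(C)[C@H](NC[C@@H]1CCCN1)c1cc(C(F)(F)F)ccc1N1CCN(C(=O)CCc2ccc(Cl)cc2Cl)CC1`: 64 nM

In an assay on HEK293 cells for displacement of a labelled ligand from Melanocortin receptor 4 (Homo sapiens) (on this read-out higher numbers stand for weaker inhibition and lower numbers for stronger inhibition), compound 3 stands second highest of the three numbers, with compound 1 nearest a 1.1-fold higher number from compound 1 to compound 3 (0.06 log units; within the scatter) and compound 2 furthest a 1.4-fold lower number from compound 2 to compound 3 (0.14 log units; within the scatter), both within the scatter. Compound 4, `CN[C@@H](CC(C)C)c1cc(C(F)(F)F)ccc1N1CCN(C(=O)CCc2ccc(Cl)cc2Cl)CC1`, differs from compound 3 by 3-methyl-1-(methylamino)butyl in place of 2-methyl-1-(((pyrrolidin-2-yl)methyl)amino)butyl on an aromatic carbon. The measured steps all change only the outer part of the amine-bearing chain and all stay within the scatter, including a 1.6-fold higher number from compound 1 to compound 2 (0.20 log units; within the scatter). None of them removes that second amine entirely, as compound 4 does, so they give little guidance. A weaker binding is expected, with compound 4 estimated at 300 nM (range 60 nM to 1500 nM), a step of a 4.7-fold higher number from compound 3 to compound 4 (0.67 log units; beyond the scatter).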

Compound 4, inhibition constant: 1900 nM
Compound 4: middle estimate off by 6.3-fold (0.80 log units), on the low side; the measured number lies above the stated range.
By their numbers in this assay, from the lowest: compounds 1, 3 and 2 (each within the scatter of the next); then compound 4.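

In this assay, exchanging the whole substituent on this aromatic carbon has a large effect (a 30-fold higher number from compound 3 to compound 4 (1.47 log units; beyond the scatter)), (a 21-fold higher number from compound 2 to compound 4 (1.33 log units; beyond the scatter)), (a 34-fold higher number from compound 1 to compound 4 (1.53 log units; beyond the scatter)), whereas the earlier changes all stayed within the scatter. Compound 1, compound 2 and compound 3 each carry two nitrogens in this substituent, while compound 4 carries one, so the earlier tolerance extends only to variations that keep the second nitrogen. Nothing available explains this loss. The change also moves the methyl branch from 2-methyl to 3-methyl, so its two parts remain unseparated. A 2-methylbutyl chain with methylamino, or a hydroxyethyl group replacing aminoethyl, would test them.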